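From compound 3 to its 4-fluorophenyl analogue, compound 4

A few compounds are considered here, and "the series" means these few. Any claim that something is new, unique, unknown or untested is made for them only; others in the source may bear on it.

For the measured compounds named here, in a functional assay on MT2 cells (Homo sapiens) for antiproliferative activity, read by MTT assay, with a stated time of 72 h (a lower number here means a stronger inhibitor of growth, a higher number a weaker inhibitor of growth), compound 3 `O=C(COc1c(-c2ccccc2)oc2ccccc2c1=O)Nc1ccccc1` gives 6720 nM, the only actual number in the set so far. Compound 1 `O=C(COc1c(-c2ccccc2)oc2ccccc2c1=O)Nc1ccc2ccccc2c1` reads > 10000 nM, which is a limit of the assay and not a number. Compound 2 `O=C(COc1ccc2oc(-c3ccccc3)cc(=O)c2c1)Nc1ccc2ccccc2c1` reads > 10000 nM, again a limit and not a number.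

Compound 4 `O=C(COc1c(-c2ccccc2)oc2ccccc2c1=O)Nc1ccc(F)cc1` differs from compound 3 by fluoro in place of hydrogen on an aromatic carbon, which turns phenyl into 4-fluorophenyl.

Going by the values given here, the only measured step is an at least 1.4-fold lower number from compound 1 to compound 3 (0.17 log units; that floor lies within the scatter). It changes the same amide-nitrogen substituent, replacing naphthalen-2-yl with phenyl, so it bears on compound 4 only indirectly. Among the compounds with values here, it also gives only a floor, and no measured step shows what fluoro does here. No shift in this assay beyond the scatter is therefore expected, in either direction.

The series also has to be read against (the limit of > 10000 nM in this assay, at which 2 of the 3 values shown sit), and compound 4 may likewise return only a limit.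

The expected change is a 1.0-fold lower number from compound 3 to compound 4 (0.01 log units; within the scatter), which is estimated to stay within the scatter. For compound 4 the estimated value is 6500 nM, with an expected range from 3300 nM to 10000 nM.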

Compound 4, concentration for 50% growth inhibition: > 10000 nM
Compound 4: a limit, no number; the forecaster's own chance of this, stated with the estimate: 25%; middle value at least 1.5-fold (0.18 log units) from the limit.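

Compound 4 reads > 10000 nM in this assay, which is a limit of the assay and not a number. Fluoro in place of hydrogen on this aromatic carbon, para to a large group, gives an at least 1.4-fold higher number from compound 3 to compound 4 (0.17 log units; that floor lies within the scatter); this is the first measured step for the change, and it shows no gain in growth inhibition from the added fluorine, while a loss beyond the scatter is not established. Compound 3 remains the only compound shown with an actual number, the step from compound 1 to compound 4 cannot be read with limits at both ends, and the amide-nitrogen substituent is now bounded mostly by one ceiling: the limit of > 10000 nM in this assay, at which 3 of the 4 values shown sit.

Going by these compounds, the true size of the fluoro step stays open, as does whether 4-fluorophenyl differs at all from phenyl once a number is available for compound 4. Also open, on these data alone, is whether a methoxy group, an amine or a carboxylic acid in place of the same hydrogen would give a measurable value in this assay, or whether a longer chain between the shared core and the amide would do so.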